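The source may report more compounds than this note shows. Statements on the series, on what has been measured and on what is new or still open speak of the compounds shown alone.

Compound 1 `CCOCC1CN(c2ccccc2)NC1=O`, compound 2 `COCCC1CN(c2ccccc2)NC1=O` and compound 3 `CN(C)CCC1CN(c2ccccc2)NC1=O` share one core and differ only in the group on a saturated ring carbon. In an assay on isolated protein for inhibition of Polyunsaturated fatty acid 5-lipoxygenase (Rattus norvegicus) (a lower number here means a stronger inhibitor, a higher number a weaker inhibitor), compound 1 gives 280 nM. In this assay compound 2 gives 480 nM; 10300 nM; 350 nM (3 entries), with one of those repeated entries far from the others (the several entries of compound 2 in this assay, 480 nM; 10300 nM; 350 nM (3 entries)). For compound 3 this assay reports only a limit, > 1000 nM (the limit of > 1000 nM in this assay, at which 1 of the 3 values shown sits). Within the data shown here, the step of an at least 3.5-fold higher number from compound 1 to compound 3 (0.55 log units; beyond the scatter) is the one measured change that bears here. Compound 4 `CCSC1CN(c2ccccc2)NC1=O` alters compound 3 by ethylsulfanyl in place of 2-(dimethylamino)ethyl on a saturated ring carbon. Since compound 1 gives 280 nM with a neutral chain, compound 4 is expected to move back in that direction, a step of an at least 2.5-fold lower number from compound 3 to compound 4 (0.39 log units; beyond the scatter). Compound 4 is estimated at 400 nM, between 120 nM and 1500 nM.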

Compound 4, half-maximal inhibitory concentration: 60 nM
For compound 4 the middle estimate is 6.7-fold (0.82 log units) above the measured one; measured number below the stated range.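

In this assay, ethylsulfanyl on this saturated ring carbon gives an at least 16-fold lower number from compound 3 to compound 4 (1.22 log units; beyond the scatter), a step that is only a minimum because compound 3 has no exact number: the limit of > 1000 nM in this assay, at which 1 of the 4 values shown sits.

Compound 4 also surpasses the ethoxymethyl chain of compound 1, with a 4.7-fold lower number from compound 1 to compound 4 (0.67 log units; beyond the scatter), so removing the dimethylamino group does not account for the whole gain.

Ethylsulfanyl differs from ethoxymethyl in both the sulfur atom and the chain, so the compounds shown cannot separate these two changes. Ethoxy on this same ring carbon, or a longer propylsulfanyl chain, would help to tell them apart.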